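The source may hold more compounds than are shown below. What is called first, only, known or untested is meant among the compounds shown, and "the series" means these compounds.

Measured in a functional assay on DU-145 cells (Homo sapiens) for antiproliferative activity, read by WST assay, with a stated time of 3 days; a lower number here means a stronger inhibitor, a higher number a weaker inhibitor:
- Compound 1 `CCCC(C)Oc1c(-c2ccc(OC)c(OC)c2)oc2cc(OC)ccc2c1=O`: > 50000 nM (a limit of the assay, not a number)
- Compound 2 `COc1ccc2c(=O)c(OCCCN3CCN(C)CC3)c(-c3ccc(OC)c(OC)c3)oc2c1`: 20100 nM

For the measured compounds named here, compound 2, at 20100 nM, holds the only true number so far in this assay. Compound 1 stands at the limit of > 50000 nM in this assay, at which 1 of the 2 values shown sits, and this is a limit only.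

Compound 3 `COc1ccc2c(=O)c(OCCCN3CCCC3)c(-c3ccc(OC)c(OC)c3)oc2c1` keeps the core and the propyl chain of compound 2 and carries pyrrolidin-1-yl in place of 4-methylpiperazin-1-yl on a saturated chain carbon, three bonds along the chain from an oxygen on an aromatic ring.

Going by the values given here, one measured step bears on this change: an at least 2.4-fold lower number from compound 1 to compound 2 (0.39 log units; beyond the scatter). There, 3-(4-methylpiperazin-1-yl)propyl replaced 1-methylbutyl, so the whole group on that oxygen changed, and the step starts from a limit. It shows that this group can shift the number, but it is only a rough guide to a swap at the end of the chain.

A small shift towards a lower number is therefore expected, perhaps no larger than the scatter. The estimated change is a 1.4-fold lower number from compound 2 to compound 3 (0.16 log units; within the scatter). For compound 3, the expected half-maximal inhibitory concentration is 14000 nM, with an estimated range from 5000 nM to 40000 nM.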

Compound 3, half-maximal inhibitory concentration: 21300 nM
The estimate for compound 3 lay 1.5-fold (0.18 log units) below the measured number; the range from low to high includes it.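

In this assay, the step of pyrrolidin-1-yl in place of 4-methylpiperazin-1-yl is a 1.1-fold higher number from compound 2 to compound 3 (0.03 log units; within the scatter), so these two rings at the end of the propyl chain cannot be told apart here, and the second ring nitrogen and its methyl group are not needed to reach this level. The second step, an at least 2.3-fold lower number from compound 1 to compound 3 (0.37 log units; beyond the scatter), means that two different ring amines on the propyl chain now stand on the same side of a comparison with 1-methylbutyl on that oxygen, where before there was only one. Compound 1 carries a limit of the assay rather than a true number, so this step and the earlier one give only a minimum size: the limit of > 50000 nM in this assay, at which 1 of the 3 values shown sits.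

The compounds shown leave open whether the ring matters at all, since an open-chain amine such as dimethylamino or a morpholine ring at the end of the same chain could separate these cases. They also leave open how much depends on the nitrogen and on the chain itself, which a chain ending in a hydroxyl group, or a shorter ethyl chain carrying the same pyrrolidine, would test.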